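The source may hold more compounds than are shown below. What is called first, only, known or untested is meant among the compounds shown, and "the series" means these compounds.

Compound 1, `N#Cc1cnc(NCc2cnccc2C(F)(F)F)cc1N[C@H]1CC[C@@H](O)CC1`, in an assay on isolated protein for inhibition of protein kinase C delta type (Homo sapiens), read by TR-FRET, with a stated time of 2 h (a lower number here means a stronger inhibitor, a higher number a weaker inhibitor), gives 4500 nM.
Compound 2, `N#Cc1cnc(NCc2cnccc2C(F)(F)F)cc1N[C@H]1CC[C@@H](c2nc[nH]n2)CC1`, gives 1200 nM.
Compound 3, `N#Cc1cnc(NCc2cnccc2C(F)(F)F)cc1N[C@H]1CC[C@@H](n2cncn2)CC1`, gives 5500 nM.

Among these three numbers compound 1 stands second highest; compound 3 is nearest, their two values within the scatter, and compound 2 is furthest, with a 3.8-fold lower number from compound 1 to compound 2 (0.57 log units; beyond the scatter). Compound 4, `CC1(C)[C@H](Nc2cc(NCc3cnccc3C(F)(F)F)ncc2C#N)C[C@H]1C(N)=O`, is not yet measured. It differs from compound 1 in one place: 3-carbamoyl-2,2-dimethylcyclobutyl in place of 4-hydroxycyclohexyl on a nitrogen on an aromatic ring.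

The measured steps all concern the group on the saturated ring carbon while the six-membered ring itself is kept. a 3.8-fold lower number from compound 1 to compound 2 (0.57 log units; beyond the scatter) was modest, a 1.2-fold higher number from compound 1 to compound 3 (0.09 log units; within the scatter) fell within the scatter, and a 4.6-fold higher number from compound 2 to compound 3 (0.66 log units; beyond the scatter) was again modest. Within the data shown here, no measured step exchanges the ring, so the change to compound 4 is only loosely bracketed by these. Exchanging the hydroxy for another group that both donates and accepts a hydrogen bond moved the number by at most a modest amount, so compound 4 is expected to show a 1.3-fold lower number from compound 1 to compound 4 (0.11 log units; within the scatter), with the range kept wide. The estimate for compound 4 is 3500 nM, between 1200 nM and 10000 nM.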

Compound 4, half-maximal inhibitory concentration: 900 nM
Compound 4: the middle estimate sits 3.9-fold (0.59 log units) above what was measured, outside the stated range (below it).
By their numbers in this assay, from the lowest: compounds 4 and 2 (each within the scatter of the next); then compounds 1 and 3 (each within the scatter of the next).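

Among these compounds, at the group on a nitrogen on an aromatic ring, the earlier compounds varied only the substituent on a retained six-membered ring, whereas here the ring itself is exchanged: 3-carbamoyl-2,2-dimethylcyclobutyl in place of 4-hydroxycyclohexyl gives a 5.0-fold lower number from compound 1 to compound 4 (0.70 log units; beyond the scatter) in this assay. The position therefore accepts a four-membered ring of carbon only, and the inhibitor gets stronger rather than weaker with this change. No measurement shown here accounts for that shift.

Because the ring, the two methyl groups and the carbamoyl group all change in one step, the compounds shown leave open which of them carries the shift. A 4-carbamoylcyclohexyl group, a cyclobutyl lacking the two methyl groups, or a carboxylic acid or amine in place of the carbamoyl group would each bear on that question.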